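Moving the acid onto a smaller ring

The source may hold more compounds than are shown below. What is called first, only, known or untested is meant among the compounds shown, and "the series" means these compounds.

Compound 1 `O=C(O)C1CCN(c2ccc(OCc3ccc(Cl)cc3Cl)cc2)C1` gives 2100 nM in a functional assay on cells for agonist activity at Free fatty acid receptor 1 (Homo sapiens), read by FLIPR and calcium flux, with a stated time of 100 s; on this read-out lower numbers stand for an effect already at smaller amounts and higher numbers for an effect only at larger amounts of compound.
Compound 2 `O=C(O)CC1CCN(c2ccc(OCc3ccc(Cl)cc3Cl)cc2)C1` gives > 33000 nM, a limit of this assay.

Compound 1 holds the only firm number shown; compound 2 gave only a limit. Compound 3 `O=C(O)C[C@@H]1CCN1c1ccc(OCc2ccc(Cl)cc2Cl)cc1` differs from compound 1 by 2-(carboxymethyl)azetidin-1-yl in place of 3-carboxypyrrolidin-1-yl on an aromatic carbon. Going by the values given here, the one measured step that bears on this is an at least 15-fold higher number from compound 1 to compound 2 (1.19 log units; beyond the scatter), a heavy loss that ends at the limit of > 33000 nM in this assay, at which 1 of the 2 values shown sits. Compound 3 carries that same carboxymethyl group, yet on the four-membered ring named in the change, so a smaller shift than that step is expected, a 1.7-fold higher number from compound 1 to compound 3 (0.22 log units; within the scatter). Compound 3 is therefore estimated at 3500 nM, within 800 nM to 16000 nM.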

Compound 3, half-maximal effective concentration: 260 nM
Estimate against measurement, compound 3: 13-fold (1.13 log units) above; the whole stated range lies above it.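

Replacing 3-carboxypyrrolidin-1-yl with 2-(carboxymethyl)azetidin-1-yl brings an 8.1-fold lower number from compound 1 to compound 3 (0.91 log units; beyond the scatter), although the atoms are the same and only joined differently. This place on the aromatic ring therefore accepts the four-membered ring carrying the acid, and a carboxymethyl group does not bring a loss in every setting. Compound 2, with that group on a five-membered ring, remains a limit: the limit of > 33000 nM in this assay, at which 1 of the 3 values shown sits.

Open, from the compounds shown here alone, is how the mirror-image form of compound 3 would behave at its one defined stereocentre. Also open, going by these compounds, is what a longer chain, such as carboxyethyl, would do on the four-membered ring.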